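Bromo for Chloro on Two Related Cores

A few compounds are considered here, and "the series" means these few. Any claim that something is new, unique, unknown or untested is made for them only; others in the source may bear on it.

Compound 1, `N#CC1=C(N)Oc2cc3oc(-c4ccccc4)cc(=O)c3c(O)c2C12C(=O)Nc1cc(Cl)ccc12`: in a functional assay on A549 cells (Homo sapiens) for antiproliferative activity, read by MTT assay, with a stated time of 48 h (a higher number here means a weaker inhibitor, a lower number a stronger inhibitor), compound 1 gives 8470 nM.
Compound 2, `N#CC1=C(N)Oc2cc3oc(-c4ccccc4)cc(=O)c3c(O)c2C12C(=O)Nc1cc(Br)ccc12`: in this assay compound 2 gives 9340 nM.
Compound 3, `CCN1C(=O)C2(C(C#N)=C(N)Oc3cc4oc(-c5ccc(OC)cc5OC)cc(=O)c4c(O)c32)c2cc(Cl)ccc21`: for compound 3 only a limit of the assay is known, > 50000 nM, namely (the limit of > 50000 nM in this assay, at which 1 of the 3 values shown sits).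

The cores of compound 1 and compound 3 differ in more than one place; that difference is not broken down here. On the first core one change is measured, (bromo in place of chloro on an aromatic carbon), and its step is a 1.1-fold higher number from compound 1 to compound 2 (0.04 log units; within the scatter). Compound 4, `CCN1C(=O)C2(C(C#N)=C(N)Oc3cc4oc(-c5ccc(OC)cc5OC)cc(=O)c4c(O)c32)c2cc(Br)ccc21`, carries the same change on the second core, (bromo in place of chloro on an aromatic carbon), at a place described in the same words.

Because a 1.1-fold higher number from compound 1 to compound 2 (0.04 log units; within the scatter) lies within the scatter, the same change is expected to move little on the second core, so the estimated step is a step that the limit leaves unreadable from compound 3 to compound 4. Compound 4 is estimated at 60000 nM, between 30000 nM and 150000 nM, and is expected most likely to be reported only as a limit.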

Compound 4, half-maximal inhibitory concentration: > 50000 nM
Compound 4: a limit, no number; the forecaster's own chance of this, stated with the estimate: 85%; the middle value lies beyond the limit too.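

No step from compound 3 to compound 4 can be read, since both compounds stand only at a limit: the limit of > 50000 nM in this assay, at which 2 of the 4 values shown sit.

The compounds shown leave open whether bromo in place of chloro changes anything on the core of compound 3.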